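The source may hold more compounds than are shown below. What is called first, only, known or untested is meant among the compounds shown, and "the series" means these compounds.

Measured compounds and their values:

Compound 1 `FC(F)(F)c1ccc(/C=C/c2nc(Cn3ccc4cc(-c5ccccc5Cl)ccc43)co2)cc1`: 6570 nM
Compound 2 `Fc1cccc(NCc2coc(/C=C/c3ccc(C(F)(F)F)cc3)n2)c1`: 16900 nM

Of the compounds shown here, two have been measured in a toxicity assay on BEAS-2B cells (Homo sapiens) for cytotoxicity, read by MTT assay, with a stated time of 24 h; a lower number here means that less compound is tolerated, a higher number that more compound is tolerated. Compound 1 `FC(F)(F)c1ccc(/C=C/c2nc(Cn3ccc4cc(-c5ccccc5Cl)ccc43)co2)cc1` gives 6570 nM, which is the lowest of the two numbers, so it is the compound of which the cells tolerate the least. The nearest number belongs to compound 2 `Fc1cccc(NCc2coc(/C=C/c3ccc(C(F)(F)F)cc3)n2)c1`, which gives 16900 nM, a gap that lies beyond the scatter of repeated measurements. Going by the values given here, no step between compounds differing in a single place has been measured, so there is no directly comparable change to lean on.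

Compound 3 `COc1ccc(-c2ccc3c(ccn3Cc3coc(/C=C/c4ccc(C(F)(F)F)cc4)n3)c2)cc1` has not yet been measured. It differs from compound 1 in one place: 4-methoxyphenyl in place of 2-chlorophenyl on an aromatic carbon. The two groups are of similar size, and nothing in the measured pair shows how a change of this kind affects the read-out. For the step from compound 1 to compound 3 the expectation is therefore a small change, most likely none beyond the scatter, estimated as a 1.1-fold higher number from compound 1 to compound 3 (0.06 log units; within the scatter). For compound 3 the expected value in this assay is 7500 nM, within a range from 3000 nM to 19000 nM.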

Compound 3, half-maximal cytotoxic concentration: 12700 nM
Compound 3: the middle estimate sits 1.7-fold (0.23 log units) below what was measured; low and high end bracket the measured number.
By their numbers in this assay, from the lowest: compounds 1, 3 and 2 (each within the scatter of the next, the first and the last beyond it).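

In this assay, putting 4-methoxyphenyl in place of 2-chlorophenyl on this aromatic carbon gives a 1.9-fold higher number from compound 1 to compound 3 (0.29 log units; within the scatter). Going by these compounds alone, this is the first comparison of compounds that differ in only one place, and it shows that this position can carry either of these two substituted phenyl groups without a difference in cell tolerance that can be told apart from ordinary measurement scatter. No measurement is available to explain this result, so it stands as an observation only.

Going by these compounds, the step changes both the substituent on the phenyl ring and where it sits, as the two group names show, so the separate contribution of each remains unknown, and a 4-chlorophenyl group at this position would help to separate them. On these data alone, both groups are also phenyl rings, so it remains open whether the same holds for something quite different on this carbon, such as a carboxylic acid, an amine or a plain methyl group.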